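Dichloro substitution and loss of cytotoxicity in two benzyl series

The compounds below may be only part of what the source reports. "The series", "measured", "known", "first", "only" and "open" are said of these compounds alone.

Measured so far:
compound 1 `ClCc1cccc(Cn2cnc3ncnc(Cl)c32)c1`: 2880 nM
compound 2 `ClCc1ccccc1Cn1cnc2ncnc(Cl)c21`: 4260 nM
compound 3 `ClCc1cccc(Cn2cnc3nc(Cl)nc(Cl)c32)c1`: > 100000 nM

In a functional assay on T47D cells (Homo sapiens) for cytotoxicity, read by sulforhodamine B assay, with a stated time of 48 h (on this read-out lower numbers stand for higher toxicity in this test and higher numbers for lower toxicity in this test), compound 1 gives 2880 nM and compound 2 gives 4260 nM; the two numbers sit within the scatter of each other. The difference between the cores of compound 1 and compound 2 is not broken down here. For compound 3 only a limit is reported, > 100000 nM. The change chloro in place of hydrogen on an aromatic carbon gave an at least 34-fold higher number from compound 1 to compound 3 (1.54 log units; beyond the scatter), a step that ends at the limit of > 100000 nM in this assay, at which 1 of the 3 values shown sits.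

Compound 4 `ClCc1ccccc1Cn1cnc2nc(Cl)nc(Cl)c21` is not yet measured. It carries the same kind of change relative to compound 2, (chloro in place of hydrogen on an aromatic carbon), and the surroundings of the place are the same in both cases. Because compound 1 showed an at least 34-fold higher number from compound 1 to compound 3 (1.54 log units; beyond the scatter), a step of similar size is expected for compound 2, a 35-fold higher number from compound 2 to compound 4 (1.55 log units; beyond the scatter). For compound 4 the estimate in this assay is 150000 nM, most likely again reported only as a limit.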

Compound 4, concentration lethal to 50% of the cells: > 100000 nM
Compound 4: a limit, no number; the forecaster's own chance of this, stated with the estimate: 70%; the middle value is on the limit's open side.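

In this assay, chloro in place of hydrogen on an aromatic carbon gives, on the second core, an at least 23-fold higher number from compound 2 to compound 4 (1.37 log units; beyond the scatter). The change therefore points the same way on both cores shown, but the sizes of the two steps cannot be set against each other: the same change on two cores in this assay, an at least 34-fold higher number (1.54 log units; beyond the scatter) from compound 1 to compound 3 and an at least 23-fold higher number (1.37 log units; beyond the scatter) from compound 2 to compound 4; the limit leaves it open whether they differ. As far as these compounds go, compound 4 is reported only as a limit, so the full size of its step remains unknown: the limit of > 100000 nM in this assay, at which 2 of the 4 values shown sit.

The compounds shown leave open what a group other than chloro, such as an amine or a methoxy group, would do on this aromatic carbon between two ring nitrogen atoms. They also leave open whether a smaller group there would give a step that can be read as a number.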